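The source may report more compounds than this note shows. Statements on the series, on what has been measured and on what is new or still open speak of the compounds shown alone.

Three measured compounds share one core: compound 1 `COc1cc(-c2nn(-c3cccc(NC(=O)Nc4cc(C(F)(F)F)cc(C(F)(F)F)c4)c3)cc2-c2ccncc2)ccc1Cl`, compound 2 `COc1cc(-c2nn(-c3cccc(NC(=O)Nc4ccc(Cl)c(Cl)c4)c3)cc2-c2ccncc2)ccc1Cl` and compound 3 `O=C(Nc1cccc(-n2cc(-c3ccncc3)c(-c3ccc(Cl)c(O)c3)n2)c1)Nc1ccc(Cl)c(Cl)c1`. In a functional assay on MDA-MB-231 cells (Homo sapiens) for inhibition, read by sulforhodamine B assay, with a stated time of 48 h (a higher number here means a weaker inhibitor of growth, a lower number a stronger inhibitor of growth), compound 1 gives 1410 nM, compound 2 gives 1920 nM, and compound 3 gives 8330 nM. Compound 2 thus stands second highest of the three numbers; compound 1 sits within the scatter of it, while compound 3 lies beyond it, as the step of a 4.3-fold higher number from compound 2 to compound 3 (0.64 log units; beyond the scatter) shows, a step that comes from hydrogen in place of methyl on an oxygen on an aromatic ring.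

Compound 4 `COc1cc(-c2nn(-c3cccc(NC(=O)c4ccc(Cl)c(C(F)(F)F)c4)c3)cc2-c2ccncc2)ccc1Cl` has not yet been measured. It differs from compound 2 in one place: 4-chloro-3-(trifluoromethyl)phenyl in place of (3,4-dichlorophenyl)amino on a carbonyl carbon. Within the data shown here, no measured step touches this part of the structure; the only step that has been measured, a 4.3-fold higher number from compound 2 to compound 3 (0.64 log units; beyond the scatter), concerns a different group, so there is no direct precedent for the change. In the absence of such a precedent, the step of a 1.0-fold higher number from compound 2 to compound 4 (0.02 log units; within the scatter) is expected to be small, most likely within the scatter, with no firm direction. Compound 4 is therefore estimated at 2000 nM in this assay, with a range running from 700 nM to 6000 nM.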

Compound 4, concentration for total growth inhibition: > 32500 nM
Compound 4: a limit, no number; the forecaster's own chance of this, stated with the estimate: 5%; middle value at least 16-fold (1.21 log units) away from the limit.
By their numbers in this assay, from the lowest: compounds 1 and 2 (each within the scatter of the next); then compound 3. At a limit, above all of these: compound 4.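

In this assay compound 4 gives no number, only a limit: the limit of > 32500 nM in this assay, at which 1 of the 4 values shown sits. Among these compounds, the step at the carbonyl carbon, an at least 16-fold higher number from compound 2 to compound 4 (1.22 log units; beyond the scatter), is large, whereas a 4.3-fold higher number from compound 2 to compound 3 (0.64 log units; beyond the scatter) is modest, so this part of the structure matters far more in this assay than the earlier compounds could suggest. Compound 1 at 1410 nM and compound 2 at 1920 nM lie within the scatter of each other, so those two aryl groups, both attached through an amino nitrogen, had pointed to tolerance here, and compound 4 shows that this tolerance does not extend to 4-chloro-3-(trifluoromethyl)phenyl set directly on the carbonyl carbon.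

The step changes two things at once, removing the amino nitrogen with its hydrogen-bond donor and altering the groups on the aromatic ring, and the compounds shown cannot separate these two changes. A compound carrying (4-chloro-3-(trifluoromethyl)phenyl)amino on the same carbonyl carbon would separate them, and a methylene or an oxygen in place of that nitrogen would test whether any other linking atom is accepted.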